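Cytotoxicity notes on a triaryl-triazole series, compounds 1 to 4

This account rests on a few compounds, and the source may have more. Where it says the series, first, only, none or still open, it means among the compounds named here.

Measured so far:
- compound 1, `CC(C)(C)c1ccc(-n2nc(-c3ccc(C(F)(F)F)cc3O)nc2-c2ccccc2O)cc1`, 81.1%
- compound 2, `COc1ccc(-n2nc(-c3ccc(C(F)(F)F)cc3O)nc2-c2ccccc2O)cc1`, 98.9%
- compound 3, `Oc1cc(C(F)(F)F)ccc1-c1nc(-c2ccccc2O)n(-c2cccc(C(F)(F)F)c2)n1`, 99.9%

All three share one core and differ only in the aryl group on the aromatic nitrogen. In a functional assay on PC-12 cells (Rattus norvegicus) for cytotoxicity, read by MTT assay, with stated times of 2 h and 24 h, tested at 10 uM (a lower number here means a weaker effect, a higher number a stronger effect of the compound at the concentration tested), compound 3 gives 99.9%, the highest of the three numbers; compound 2 sits within the scatter of it, and only compound 1 lies beyond the scatter, lower. The two informative steps are a number 17.8 percentage points higher from compound 1 to compound 2 (beyond the scatter) and a number 18.8 percentage points higher from compound 1 to compound 3 (beyond the scatter), whereas a number 1 percentage points higher from compound 2 to compound 3 (within the scatter).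

The next compound is compound 4, `Oc1cc(C(F)(F)F)ccc1-c1nc(-c2ccccc2O)n(-c2cc(F)cc(F)c2)n1`. Relative to compound 3 the change is 3,5-difluorophenyl in place of 3-(trifluoromethyl)phenyl on an aromatic nitrogen.

The step that bears most directly on this one is the swap of aryl groups on the aromatic nitrogen between compound 2 and compound 3, which stayed within the scatter even though the two groups differ considerably. Only the tert-butyl-bearing aryl of compound 1 gave a lower number. Because compound 3 already gives 99.9%, there is little room above it, so the expectation for this assay is a step of a number 4.9 percentage points lower from compound 3 to compound 4 (within the scatter), no larger than the scatter. Compound 4 is estimated at 95%, with a range from 80% to 100%.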

Compound 4, a percentage reported as activity, at one concentration (the size of the read-out at that concentration, not a potency): 106%
The estimate for compound 4 lay 11 percentage points below the measured number; measured number above the stated range.
By their numbers in this assay, from the lowest: compound 1; then compounds 2, 3 and 4 (each within the scatter of the next).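

In this assay, a third aryl group on the aromatic nitrogen gives no separable change, with a number 6.1 percentage points higher from compound 3 to compound 4 (within the scatter) and a number 7.1 percentage points higher from compound 2 to compound 4 (within the scatter) in the same breath. For the compounds shown here, replacing the single trifluoromethyl with two fluorine atoms as 3,5-difluorophenyl therefore cannot be told apart from 3-(trifluoromethyl)phenyl or 4-methoxyphenyl at this position, while compound 1 remains the only compound set apart, with a number 24.9 percentage points higher from compound 1 to compound 4 (beyond the scatter) and its 4-(tert-butyl)phenyl group on the same nitrogen. No measurement shown here accounts for why compound 1 stands apart or why compounds 2, 3 and 4 do not separate from one another.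

Still open, going by these compounds, is whether the lower number of compound 1 follows the tert-butyl group wherever it sits on this aryl ring, as 3-(tert-butyl)phenyl would show, given that 4-methoxyphenyl in compound 2 does not share that lower number. Also open, on these data alone, is whether an aryl group carrying an amine or a carboxylic acid, or a longer alkyl chain in place of the aryl group, would separate from compounds 2, 3 and 4 at this nitrogen.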